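A few compounds are considered here, and "the series" means these few. Any claim that something is new, unique, unknown or untested is made for them only; others in the source may bear on it.

Compound 1 `C(=C/c1cccc(-c2nn[nH]n2)c1)\c1cccc(OCc2ccc3ccccc3n2)c1`: 20 nM
Compound 2 `c1cc(COc2ccc(OCc3ccc4ccccc4n3)cc2)cc(-c2nn[nH]n2)c1`: 2 nM

Both compounds were tested in a functional assay (lung) for inhibition, with Cavia porcellus as the target; a higher number here means a weaker inhibitor, a lower number a stronger inhibitor. Compound 2, at 2 nM, has the lower of the two numbers and so is the stronger inhibitor. Compound 1 stands at 20 nM, and the gap between the two lies beyond the scatter. These two compounds differ in more than one place, so their values say nothing directly about the next change.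

Compound 3 `c1cc(COc2ccc(OCc3ccc4ccccc4n3)cc2)cc(OCc2nn[nH]n2)c1` keeps the rest of compound 2 and changes one group: (2H-tetrazol-5-yl)methoxy in place of 2H-tetrazol-5-yl on an aromatic carbon. It carries (2H-tetrazol-5-yl)methoxy in place of 2H-tetrazol-5-yl on an aromatic carbon, meta to a large group. Within the data shown here, no measured pair shows this exchange, so the expectation is a loose one. With compound 2 already at 2 nM, a moderate move toward a higher number in this assay is expected, though a step within the scatter would not be surprising. The expected change is a 3.0-fold higher number from compound 2 to compound 3 (0.48 log units; beyond the scatter). For compound 3 the estimated value is 6 nM, with an expected range from 1.5 nM to 25 nM.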

Compound 3, half-maximal inhibitory concentration: 9 nM
Estimate against measurement, compound 3: 1.5-fold (0.18 log units) below; the range from low to high includes it.
By their numbers in this assay, from the lowest: compound 2; then compound 3; then compound 1.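

In this assay, moving from 2H-tetrazol-5-yl to (2H-tetrazol-5-yl)methoxy on this aromatic carbon, meta to a large group, gives a 4.5-fold higher number from compound 2 to compound 3 (0.65 log units; beyond the scatter), a real but modest step. Among these compounds, this is the first reading at this position, and it shows that the five-membered aromatic ring need not stand directly on the aromatic carbon for strong inhibition: with the larger group in place, compound 3 still reads 9 nM in this assay, so the change weakens inhibition without abolishing it. Nothing measured on these compounds offers an explanation for the size of this step.

The compounds shown leave open whether the step comes from the added oxygen or from the added carbon, as both enter together in this one exchange. A (2H-tetrazol-5-yl)methyl group on the same aromatic carbon would bear on that question, while a carboxylic acid or a longer chain there would show whether the position depends on the tetrazole ring and how much further length it accepts.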